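From a Piperidine Amide to a Dimethylamide

This account rests on a few compounds, and the source may have more. Where it says the series, first, only, none or still open, it means among the compounds named here.

Of the compounds shown here, three have been measured so far in an assay on HEK-293T cells for inhibition of phospholipase A and acyltransferase 4 (Homo sapiens), with stated times of 30 min and 20 min (a higher number here means a weaker inhibitor, a lower number a stronger inhibitor), and none of them gave a number. Compound 1 `O=C(CCc1ccccc1)C(F)(F)C(=O)NCc1ccccc1` returned only the limit of > 10000 nM. Compound 2 `O=C(CCc1ccccc1)[C@H](F)C(=O)NCc1ccccc1` likewise returned only the limit of > 10000 nM. Compound 3 `O=C(CCc1ccc(Cl)cc1)C(=O)N1CCCCC1`, too, sits at the limit of > 10000 nM. Where compound 3 stands is thus known only as a bound, shared with the other two, as captured by the limit of > 10000 nM in this assay, at which 3 of the 3 values shown sit; no order among the three can be drawn from it, and none of them can be called weaker or stronger than another.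

Compound 4 `CN(C)C(=O)C(=O)CCc1ccc(Cl)cc1` keeps the rest of compound 3 and changes one group: dimethylamino in place of piperidin-1-yl on a carbonyl carbon. Among the compounds with values here, no step between two measured compounds is available to gauge the effect of this change, and the three values shown give no direction. No step beyond the usual scatter is expected, and the expected step is a step that the limit leaves unreadable from compound 3 to compound 4. Compound 4 is estimated at 15000 nM, in a range from 5000 nM to 50000 nM, with a strong chance that this assay once more reports only a limit.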

Compound 4, half-maximal inhibitory concentration: > 10000 nM
Compound 4 was reported as a limit; the forecaster's own chance of this, stated with the estimate: 85%; the middle value does not contradict the limit.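

Compound 3 and compound 4 each gave only a limit, so no step between them can be read, and the same holds for all the compounds shown: the limit of > 10000 nM in this assay, at which 4 of the 4 values shown sit. What they leave open is whether any change to the shared core gives a number in this assay rather than a limit, and how these four compounds rank.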